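This account rests on a few compounds, and the source may have more. Where it says the series, first, only, none or still open, it means among the compounds named here.

Working notes on the series. Compound 1 `O=C(CCCCCc1cccc(O)c1)N1CCOC1=O` gives 8640 nM in an assay on HEK293 cells for inhibition of N-acylethanolamine-hydrolyzing acid amidase (Rattus norvegicus), read by LC-MS, with a stated time of 30 min; a lower number here means a stronger inhibitor, a higher number a weaker inhibitor. Compound 2 `CSc1ccc(CCCCCC(=O)N2CCOC2=O)cc1` stands at a limit of this assay, > 20000 nM, so that only a bound and no number is known for it, as recorded in the limit of > 20000 nM in this assay, at which 1 of the 2 values shown sits. Compound 3 `NC(=O)c1ccc(CCCCCC(=O)N2CCOC2=O)cc1` is not yet measured in this assay. It carries carbamoyl in place of methylsulfanyl on an aromatic carbon, that is carbamoyl in place of methylsulfanyl on an aromatic carbon. From the bound on compound 2, the step of an at least 1.3-fold lower number from compound 2 to compound 3 (0.12 log units; that floor lies within the scatter) is expected to be small, with either direction possible. Compound 3 is estimated at 15000 nM in this assay, with a range of 4000 nM to 40000 nM.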

Compound 3, half-maximal inhibitory concentration: > 20000 nM
Compound 3 was reported as a limit; the forecaster's own chance of this, stated with the estimate: 45%; at least 1.3-fold (0.12 log units) between middle value and limit.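

No step can be read from compound 2 to compound 3, as both stand at a limit and neither has a number: the limit of > 20000 nM in this assay, at which 2 of the 3 values shown sit. The compounds shown leave open whether carbamoyl in place of methylsulfanyl changes the result at all in this assay.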